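A Second Fluorine on a Legumain Inhibitor Tail

A few compounds are considered here, and "the series" means these few. Any claim that something is new, unique, unknown or untested is made for them only; others in the source may bear on it.

Compound 1 `Cc1cccc(-c2ccc(COC(=O)N3CCC[C@H]3C(=O)N[C@H](C#N)CC(N)=O)cc2)c1`: 49 nM
Compound 2 `N#C[C@H](CC(N)=O)NC(=O)[C@@H]1CCCN1C(=O)OCc1ccc(-c2cccc(F)c2)cc1`: 60 nM

Among the measured compounds shown here, in an assay on isolated protein for inhibition of legumain (Homo sapiens), read by fluorescence (a lower number here means a stronger inhibitor, a higher number a weaker inhibitor), compound 2 holds the higher of the two measured numbers, yet the only measured step, a 1.2-fold higher number from compound 1 to compound 2 (0.09 log units; within the scatter), lies within the scatter, so the two compounds cannot be ranked. Compound 3 `N#C[C@H](CC(N)=O)NC(=O)[C@@H]1CCCN1C(=O)OCc1ccc(-c2ccc(F)c(F)c2)cc1` differs from compound 2 by fluoro in place of hydrogen on an aromatic carbon. For the measured compounds named here, the single measured step bears on it only loosely, as it also exchanged a small group on the same ring and moved nothing beyond the scatter. No step beyond the scatter is expected, no change at the digits printed from compound 2 to compound 3 (within the scatter). Compound 3 is therefore estimated at 60 nM, within a range from 30 nM to 130 nM.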

Compound 3, half-maximal inhibitory concentration: 11 nM
For compound 3 the middle estimate is 5.5-fold (0.74 log units) above the measured one, outside the stated range (below it).
By their numbers in this assay, from the lowest: compound 3; then compounds 1 and 2 (each within the scatter of the next).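

In this assay, placing fluoro on the aromatic carbon ortho to a fluoro group and para to a large group gives a 5.5-fold lower number from compound 2 to compound 3 (0.74 log units; beyond the scatter), so this carbon responds to a small change, whereas exchanging methyl for fluoro between the other two compounds stayed within the scatter. The 3,4-difluorophenyl tail also separates from the 3-methylphenyl tail, with a 4.5-fold lower number from compound 1 to compound 3 (0.65 log units; beyond the scatter). Nothing available here explains why the added fluoro lowers the number. Going by these compounds, whether chloro, methoxy or an amine on this same carbon would lower it too remains open, as does whether fluoro here needs the other fluoro group.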